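This account rests on a few compounds, and the source may have more. Where it says the series, first, only, none or still open, it means among the compounds named here.

Measured so far:
Compound 1 `COc1cc(C=C(C(=O)/C=C/c2cccc(OC)c2OC)C(=O)/C=C/c2cccc(OC)c2OC)ccc1O`: 130 nM
Compound 2 `COc1cccc(/C=C/C(=O)C(=Cc2ccc(OC)c(OC)c2OC)C(=O)/C=C/c2cccc(OC)c2OC)c1OC`: 260 nM

In a functional assay on A549 cells (Homo sapiens) for antiproliferative activity, read by sulforhodamine B assay, with a stated time of 48 h (on this read-out lower numbers stand for stronger inhibition and higher numbers for weaker inhibition), compound 1 gives 130 nM, and compound 2 gives 260 nM. Compound 1 stands at the lower of the two numbers, but a 2.0-fold higher number from compound 1 to compound 2 (0.30 log units; within the scatter), so the two are not separated by the measurement. Compound 3 `COc1ccc(C=C(C(=O)/C=C/c2cccc(OC)c2OC)C(=O)/C=C/c2cccc(OC)c2OC)cc1O` is the next candidate. It differs from compound 1 as follows: 3-hydroxy-4-methoxyphenyl in place of 4-hydroxy-3-methoxyphenyl on a double-bonded chain carbon bound to a double-bonded chain carbon. Going by the values given here, no measured step exchanges a hydroxy and a methoxy group on that ring; the only measured step at the same place is the one to compound 2, a different replacement, and it stayed within the scatter. On that basis no step beyond the scatter is expected for compound 3 either. Compound 3 is therefore estimated at 150 nM, with a range from 60 nM to 400 nM, which would mean a 1.2-fold higher number from compound 1 to compound 3 (0.06 log units; within the scatter) as the expected step.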

Compound 3, half-maximal inhibitory concentration: 270 nM
Beside the measured number, compound 3's estimate is 1.8-fold (0.26 log units) below it; measured number inside the range.
By their numbers in this assay, from the lowest: compounds 1, 2 and 3 (each within the scatter of the next, the first and the last beyond it).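

In this assay, exchanging 4-hydroxy-3-methoxyphenyl for 3-hydroxy-4-methoxyphenyl gives a 2.1-fold higher number from compound 1 to compound 3 (0.32 log units; beyond the scatter) even though the group keeps the same atoms and counts, so this position shows a modest response to how the hydroxy and methoxy groups are arranged on the ring, not only to which groups are present. At the same place, the change gives a 1.0-fold higher number from compound 2 to compound 3 (0.02 log units; within the scatter) and thus does not separate 3-hydroxy-4-methoxyphenyl from 2,3,4-trimethoxyphenyl, although only the former carries a hydroxy group. No available evidence bears on this modest difference.

The compounds shown carry only hydroxy and methoxy groups on this ring, so it remains open how an amine or a carboxylic acid would fare there. Also open, from the compounds shown here alone, is whether an ethoxy group in place of the methoxy group would keep the number of compound 1 130 nM in this assay.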